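Compound 3: Expected Response After a Ring Swap

The compounds below may be only part of what the source reports. "The series", "measured", "known", "first", "only" and "open" are said of these compounds alone.

In a functional assay on CHO-RD-HGA16 cells for agonist activity at Orexin/Hypocretin receptor type 1 (Homo sapiens), read by fluorescence and calcium flux, with a stated time of 30 min (on this read-out higher numbers stand for larger maximal responses and lower numbers for smaller maximal responses), compound 2 `COc1ccc(-c2cccc(C(=O)N(C)C)n2)cc1S(=O)(=O)Nc1cccc(NCCNC(=O)c2cccc(C)c2)c1` gives 100%, and compound 1 `COc1ccc(-c2cncc(C(=O)N(C)C)c2)cc1S(=O)(=O)Nc1cccc(NCCNC(=O)c2cccc(C)c2)c1` gives 105%; the two values lie within the scatter of each other, so neither stands apart. Within the data shown here, the only measured step, a number 5 percentage points lower from compound 1 to compound 2 (within the scatter), exchanged one dimethylcarbamoyl-bearing aromatic group for another and stayed within the scatter. Compound 3 `COc1ccc(-c2csc(C(=O)N(C)C)c2)cc1S(=O)(=O)Nc1cccc(NCCNC(=O)c2cccc(C)c2)c1` differs from compound 2 by 5-(dimethylcarbamoyl)thiophen-3-yl in place of 6-(dimethylcarbamoyl)pyridin-2-yl on an aromatic carbon. Since the earlier exchange of this group left the maximal response unchanged, a step of no change at the digits printed from compound 2 to compound 3 (within the scatter) is expected, none beyond the scatter. Compound 3 is therefore estimated at 100%, ranging from 85% to 115%.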

Compound 3, largest response reached (Emax), in percent of the reference or control that the assay uses: 59%
Beside the measured number, compound 3's estimate is 41 percentage points above it; measured number outside the range, below it.
By their numbers in this assay, from the lowest: compound 3; then compounds 2 and 1 (each within the scatter of the next).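

In this assay, this position turns out to be sensitive to the ring that carries the dimethylcarbamoyl group: the 5-(dimethylcarbamoyl)thiophen-3-yl group gives a number 41 percentage points lower from compound 2 to compound 3 (beyond the scatter) and a number 46 percentage points lower from compound 1 to compound 3 (beyond the scatter). The two pyridine-bearing groups lie within the scatter of each other, so exchanging the aromatic ring here is not always tolerated. Nothing available here accounts for the drop. Still open, going by these compounds, is whether the loss follows the thiophene ring itself, and how a phenyl ring bearing the same dimethylcarbamoyl group, or a thiophene bearing a carboxylic acid instead, would respond.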